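The compounds below may be only part of what the source reports. "The series", "measured", "known", "first", "only" and "open" are said of these compounds alone.

Measured so far in an ADME assay on MT4 cells (Homo sapiens) for cytotoxicity, read by MTT assay, with a stated time of 4 days; a higher number here means that more compound is tolerated, a lower number that less compound is tolerated: compound 1 `Cc1ccc(OCCn2ccc(=O)n(Cc3ccccc3)c2=O)cc1` at 187000 nM; compound 2 `CC(C)(C)c1ccc(OCCn2ccc(=O)n(Cc3ccccc3)c2=O)cc1` at 63000 nM.

Compound 2 holds the lowest of the two numbers; the nearest, and only, comparison is compound 1, which sits higher by a 3.0-fold lower number from compound 1 to compound 2 (0.47 log units; beyond the scatter). Among the measured compounds shown here, that single step, tert-butyl in place of methyl on an aromatic carbon, is the only measured step so far and it went downward, beyond the scatter.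

Compound 3 `O=c1ccn(CCOc2ccc(-c3ccccc3)cc2)c(=O)n1Cc1ccccc1` has not yet been measured. Its difference from compound 2 is phenyl in place of tert-butyl on an aromatic carbon, para to a large group. For the measured compounds named here, the one step that bears on it is the exchange at this same position from compound 1 to compound 2, where the number fell by a 3.0-fold lower number from compound 1 to compound 2 (0.47 log units; beyond the scatter). Going by the values given here, on that basis a further modest fall is expected in this assay, though with only one prior step the direction is not firmly anchored and a result within the scatter of compound 2 would not surprise. The expected step is a 2.1-fold lower number from compound 2 to compound 3 (0.32 log units; beyond the scatter). For compound 3 the estimate is 30000 nM, with a range from 12000 nM to 80000 nM.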

Compound 3, half-maximal cytotoxic concentration: 31000 nM
Compound 3: middle estimate off by 1.0-fold (0.01 log units), on the low side; the range from low to high includes it.
By their numbers in this assay, from the lowest: compound 3; then compound 2; then compound 1.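

In this assay, the aromatic carbon para to a large group now gives a second fall (a 2.0-fold lower number from compound 2 to compound 3 (0.31 log units; beyond the scatter)), so the downward movement is not limited to the exchange of methyl for tert-butyl. It persists when the entering group is phenyl, which brings a six-membered aromatic ring of carbon only and two more heavy atoms than tert-butyl, with hydrogen-bond donors and acceptors unchanged at zero. Over the full exchange of methyl for phenyl the change is larger (a 6.0-fold lower number from compound 1 to compound 3 (0.78 log units; beyond the scatter)), the three compounds fall into the order methyl, tert-butyl, phenyl with none going against it, and no information at hand accounts for that order.

Among the compounds shown here, with only three groups at one position, it remains open whether the order tracks heavy-atom count, ring content or something else, and whether a group carrying hydrogen-bond donors or acceptors, such as an amine or a carboxylic acid, would continue the fall or reverse it. On these data alone, the shared core stays constant throughout, so the effect of a longer chain in place of the link to the aromatic ring, or of any change to the benzyl group, also remains untested in these compounds.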